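Chain extension on the thienopyrimidinone series

The source may report more compounds than this note shows. Statements on the series, on what has been measured and on what is new or still open speak of the compounds shown alone.

Among the measured compounds shown here, compound 1 `CCCCCCc1cc2c(=O)n(CCSc3nc(-c4cc(OC)c(OC)c(OC)c4)c(C#N)c(=O)[nH]3)cnc2s1` is the only member with a number: in an ADME assay on THP-1 cells (Homo sapiens) for inhibition, read by MTT assay (a lower number here means a stronger inhibitor of growth, a higher number a weaker inhibitor of growth), compound 1 gives 96.4 ug/mL. Compound 2 `CCCc1cc2c(=O)n(CCCSc3nc(-c4cc(OC)c(OC)c(OC)c4)c(C#N)c(=O)[nH]3)cnc2s1` gives in this assay > 100 ug/mL, which is a limit of the assay and not a number. The other value shown sits at the limit of > 100 ug/mL in this assay, at which 1 of the 2 values shown sits. Compound 3 `CCCCCCCc1cc2c(=O)n(CCSc3nc(-c4cc(OC)c(OC)c(OC)c4)c(C#N)c(=O)[nH]3)cnc2s1` differs from compound 1 by methyl in place of hydrogen on a saturated chain carbon, six bonds along the chain from an aromatic carbon. For the measured compounds named here, no step between measured compounds exists here; in this assay the change is expected to stay within the scatter, with no clear direction. The step is estimated as a 1.0-fold lower number from compound 1 to compound 3 (0.01 log units; within the scatter). Compound 3 is expected at 95 ug/mL, between 50 ug/mL and 160 ug/mL, with a real chance of a limit instead.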

Compound 3, concentration for 50% growth inhibition: 88.1 ug/mL
Beside the measured number, compound 3's estimate is 1.1-fold (0.03 log units) above it; the range from low to high includes it.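

In this assay, methyl in place of hydrogen on a saturated chain carbon, six bonds along the chain from an aromatic carbon, gives a 1.1-fold lower number from compound 1 to compound 3 (0.04 log units; within the scatter). Among the compounds shown here, this is the first readable step, and it shows no effect on growth inhibition beyond the scatter at this position. Compound 2 remains a limit and not a number: the limit of > 100 ug/mL in this assay, at which 1 of the 3 values shown sits. For the compounds shown here, compound 2 differs from compound 1 in more than one place and gives no step. Open, on these data alone, is whether an amine or a carboxylic acid at the chain end, in place of methyl, would give a step beyond the scatter.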